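The source may hold more compounds than are shown below. What is called first, only, known or untested is meant among the compounds shown, and "the series" means these compounds.

Measured compounds:
compound 1 `O=C(Nc1ccccc1)C(Cl)Cl` — "not determined" (no result reported)
compound 2 `O=C(Nc1cccc(F)c1)C(Cl)Cl` — "not determined" (no result reported)
compound 3 `O=C(Nc1cccc(Br)c1)C(Cl)Cl` — 8180 nM

In a functional assay on KB cells (Homo sapiens) for antiproliferative activity, read by MTT assay, with a stated time of 72 h (on this read-out higher numbers stand for weaker inhibition and lower numbers for stronger inhibition), compound 1 has no number of its own, and compound 2 likewise gives "not determined" (no result reported). The only figure in the set belongs to compound 3, which in this assay gives 8180 nM. The change from compound 1 to compound 4 `O=C(Nc1ccc(Br)cc1)C(Cl)Cl` is bromo in place of hydrogen on an aromatic carbon. Among the compounds with values here, no step between measured compounds bears on this change, so nothing here fixes its size; a modest shift in either direction, or none beyond the scatter, is as likely as anything. Taking compound 3 as the nearest measured point, compound 4 is expected to give about 8000 nM in this assay, within a range from 2500 nM to 25000 nM.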

Compound 4, half-maximal inhibitory concentration: 21700 nM
Compound 4: middle estimate off by 2.7-fold (0.43 log units), on the low side; the range from low to high includes it.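

No new step can be read from compound 4: compound 1 offers no single number to set against it. On these data alone, what bromo in place of hydrogen does to antiproliferative activity stays open. Nothing shown here accounts for the result for compound 4.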